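The source may report more compounds than this note shows. Statements on the series, on what has been measured and on what is new or still open speak of the compounds shown alone.

In an in vivo ADME assay on the whole organism (plasma) for pharmacokinetics, with Rattus norvegicus as the target, at a dose of 5 mg/kg by the intravenous route (a higher number here means faster removal of the compound, a lower number slower removal), compound 1 (`CCC(CSC(CCc1ccccc1C(=O)O)c1cccc(OCc2ccc3ccc(Cl)cc3n2)c1)C(=O)O`) gives 8.8 mL/min/kg. Compound 2 (`CCC(CSC(CCc1ccccc1C(=O)NS(=O)(=O)c1ccccc1C)c1cccc(OCc2ccc3ccc(Cl)cc3n2)c1)C(=O)O`) gives 15 mL/min/kg and compound 3 (`CCC(CSC(CCc1ccccc1C#N)c1cccc(CCc2ccc3ccc(Cl)cc3n2)c1)C(=O)O`) gives 13 mL/min/kg, so all three numbers lie within the usual scatter of one another. Compound 4 (`CCC(CSC(CCc1ccccc1-c1nnnn1C)c1cccc(OCc2ccc3ccc(Cl)cc3n2)c1)C(=O)O`) has not yet been measured. It keeps the core of compound 1 and changes one group: 1-methyl-1H-tetrazol-5-yl in place of carboxy on an aromatic carbon. In short, 1-methyl-1H-tetrazol-5-yl stands in place of carboxy on an aromatic carbon. For the measured compounds named here, only one measured step alters this same carboxy, and it is a 1.7-fold higher number from compound 1 to compound 2 (0.23 log units; within the scatter). That step stays within the scatter. Compound 3 also lacks the carboxy, carrying a nitrile instead, but it differs elsewhere too, so it offers only a loose comparison at 13 mL/min/kg. Neither compound suggests a large change in this assay, so at most a small rise is expected, and none beyond the scatter. The estimated size of the change is a 1.4-fold higher number from compound 1 to compound 4 (0.13 log units; within the scatter). For compound 4, the expected clearance is 12 mL/min/kg, with an estimated range of 6 mL/min/kg to 24 mL/min/kg.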

Compound 4, clearance: 18 mL/min/kg
Estimate against measurement, compound 4: 1.5-fold (0.18 log units) below; the range from low to high includes it.
By their numbers in this assay, from the lowest: compounds 1, 3, 2 and 4 (each within the scatter of the next, the first and the last beyond it).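

In this assay, for the compounds shown here, a 2.0-fold higher number from compound 1 to compound 4 (0.31 log units; beyond the scatter), so this is the first replacement of the carboxy on this aromatic carbon that moves clearance beyond the scatter, though only modestly; the earlier step at the same place, a 1.7-fold higher number from compound 1 to compound 2 (0.23 log units; within the scatter), stayed within it. Compound 2 and compound 4 lie within the scatter of each other, so the two replacements, a sulfonyl amide and a 1-methyl-1H-tetrazol-5-yl ring, cannot be told apart here. No measurement shown explains why clearance rises with this change.

From the compounds shown here alone, it remains open whether the ring itself or its methyl accounts for the step, a question that the unmethylated 1H-tetrazol-5-yl group could address. A simple primary amide or a methyl ester at this place would show how other replacements of the carboxy behave.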